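The compounds below may be only part of what the source reports. "The series", "measured", "known", "first", "only" and "open" are said of these compounds alone.

Of the compounds shown here, two built on one shared core have been tested in a functional assay on U-87MG ATCC cells for antiproliferative activity against U-87 MG (Homo sapiens), read by MTT assay, with a stated time of 48 h; on this read-out lower numbers stand for stronger inhibition and higher numbers for weaker inhibition. Going by the values given here, compound 1 `C/C(=C\CC/C(C)=C/CC[C@@H]1[C@@]2(C)CCC(=O)C(C)(C)[C@H]2CC[C@@]1(C)O)CC/C=C(\C)C(=O)OCc1cn(-c2cccc(Br)c2)nn1` gives 8750000 nM in this assay, a very weak effect, and it is the only compound here with an outright number. Compound 2 `C/C(=C\CC/C(C)=C/CC[C@@H]1[C@@]2(C)CCC(=O)C(C)(C)[C@H]2CC[C@@]1(C)O)CC/C=C(\C)C(=O)OCc1cn([C@@H]2C[C@@H](n3cc(C)c(=O)[nH]c3=O)O[C@H]2CO)nn1` reaches only a limit of the assay, > 150000 nM, so for it no number is known. Of the two values shown, one sits at the limit of > 150000 nM in this assay, at which 1 of the 2 values shown sits.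

Compound 3 `C/C(=C\CC/C(C)=C/CC[C@@H]1[C@@]2(C)CCC(=O)C(C)(C)[C@H]2CC[C@@]1(C)O)CC/C=C(\C)C(=O)OCc1cn(-c2cccc(O)c2)nn1` has not yet been measured. It differs from compound 1 in one place: hydroxy in place of bromo on an aromatic carbon. A bromo group leaves and a hydroxy group enters on an aromatic carbon of a six-membered aromatic ring of carbon only. Among the compounds with values here, no measured pair of compounds shows this change, so its effect cannot be read from these data. Given how weak compound 1 is at 8750000 nM, a step no larger than the usual scatter is expected, in no particular direction. Compound 3 is therefore expected to give about 6000000 nM, with a likely range from 1500000 nM to 25000000 nM. The expected step is a 1.5-fold lower number from compound 1 to compound 3 (0.16 log units; within the scatter).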

Compound 3, half-maximal inhibitory concentration: > 150000 nM
Compound 3 gave a limit, no number (the forecaster's own chance of this, stated with the estimate: 30%); the middle value does not contradict the limit.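

In this assay, going by these compounds alone, compound 3 gives only a limit, > 150000 nM, and not a number, so no step from compound 1 to compound 3 can be read. The compounds shown leave open whether hydroxy in place of bromo on the aromatic carbon changes the antiproliferative effect at all, and in which direction and by how much.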